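From a dichloropyridinyloxy arm to a small lactam ring

The compounds below may be only part of what the source reports. "The series", "measured", "known", "first", "only" and "open" are said of these compounds alone.

Of the compounds shown here, three sharing one core have been measured in an assay for inhibition of inositol hexakisphosphate kinase 2 (Homo sapiens), read by colorimetric assay, coupled enzyme assay and malachite green, with a stated time of 120 min, in the presence of a further agent that is not named here; a higher number here means a weaker inhibitor, a lower number a stronger inhibitor. Compound 1 `O=C(O)c1ccc2noc(-c3ccc(N4CCCCC4)cc3)c2c1` gives 240 nM, compound 2 `O=C(O)c1ccc2noc(-c3ccc(Oc4ccccc4)cc3)c2c1` gives 280 nM, and compound 3 `O=C(O)c1ccc2noc(-c3ccc(Oc4ncc(Cl)cc4Cl)cc3)c2c1` gives 650 nM, the highest of the three numbers. The steps that reach compound 3 are modest but beyond the scatter: a 2.7-fold higher number from compound 1 to compound 3 (0.43 log units; beyond the scatter) and a 2.3-fold higher number from compound 2 to compound 3 (0.37 log units; beyond the scatter), whereas a 1.2-fold higher number from compound 1 to compound 2 (0.07 log units; within the scatter).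

Compound 4 `O=C(O)c1ccc2noc(-c3ccc(N4CCCC4=O)cc3)c2c1` has not yet been measured in this assay. It differs from compound 3 in one place: 2-oxopyrrolidin-1-yl in place of (3,5-dichloropyridin-2-yl)oxy on an aromatic carbon. Of the measured steps, a 2.7-fold higher number from compound 1 to compound 3 (0.43 log units; beyond the scatter) bears most directly on this change. Compound 1 likewise carries a nitrogen-linked ring at that carbon. a 2.3-fold higher number from compound 2 to compound 3 (0.37 log units; beyond the scatter) shows the same direction for the loss of the dichloropyridinyl piece. Both steps ran toward a higher number when the group that now leaves was introduced, so undoing it points toward a lower number. Among the compounds with values here, no measured compound carries a 2-oxopyrrolidin-1-yl group, so the size of the step remains uncertain. For compound 4 the expected step is a 2.2-fold lower number from compound 3 to compound 4 (0.34 log units; beyond the scatter). The estimate for compound 4 is 300 nM, with a range from 120 nM to 900 nM.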

Compound 4, half-maximal inhibitory concentration: 480 nM
Compound 4: middle estimate off by 1.6-fold (0.20 log units), on the low side; measured number inside the range.
By their numbers in this assay, from the lowest: compounds 1, 2, 4 and 3 (each within the scatter of the next, the first and the last beyond it).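

In this assay, the 2-oxopyrrolidin-1-yl group on this aromatic carbon, para to a large group, gives a number that cannot be separated from any of the earlier three: the steps are within the scatter in every case (a 1.4-fold lower number from compound 3 to compound 4 (0.13 log units; within the scatter); a 1.7-fold higher number from compound 2 to compound 4 (0.23 log units; within the scatter); a 2.0-fold higher number from compound 1 to compound 4 (0.30 log units; within the scatter)). The earlier compounds shown here held one step beyond the scatter between a piperidin-1-yl or phenoxy group and the (3,5-dichloropyridin-2-yl)oxy group, whereas compound 4, with a five-membered non-aromatic ring and a double bond outside aromatic rings, falls within the scatter of all three, so it does not side with either end of that gap. Thus a non-aromatic ring carrying a carbonyl is accommodated at this carbon with no step beyond the scatter, though nothing at hand accounts for any of these numbers.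

The compounds shown leave open how a plain pyrrolidin-1-yl group, the same ring without its carbonyl, would compare with the 2-oxopyrrolidin-1-yl group at this carbon. Also open, on these data alone, is where an open-chain acetamide or a morpholin-4-yl ring would fall at the same place.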